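Replacing the (2-aminophenyl)carbamoyl group of compound 3

The source may hold more compounds than are shown below. What is called first, only, known or untested is meant among the compounds shown, and "the series" means these compounds.

In a functional assay on A549 cells (Homo sapiens) for antiproliferative activity, read by MTT assay, with a stated time of 48 h (a higher number here means a weaker inhibitor of growth, a lower number a stronger inhibitor of growth), compound 1 `CCOc1cc(NC(=O)CCCCCCC(=O)Nc2ccccc2N)cc2c1OCC([N+](=O)[O-])=C2` gives 11700 nM and compound 2 `CCOc1cc(NC(=O)CCCCC(=O)Nc2ccccc2N)cc2c1OCC([N+](=O)[O-])=C2` gives 9630 nM while compound 3 `CCOc1cc(NC(=O)CCCCCC(=O)Nc2ccccc2N)cc2c1OCC([N+](=O)[O-])=C2` gives 12200 nM and so stands within the scatter of both. Going by the values given here, the only measured steps are a 1.0-fold higher number from compound 1 to compound 3 (0.02 log units; within the scatter) and a 1.3-fold higher number from compound 2 to compound 3 (0.10 log units; within the scatter) and both lie within the scatter. Compound 4 `CCOc1cc(NC(=O)CCCCCNC(=O)CCCc2ccccc2)cc2c1OCC([N+](=O)[O-])=C2` carries ((3-phenylpropyl)carbonyl)amino in place of (2-aminophenyl)carbamoyl on a saturated chain carbon, five bonds along the chain from a carbonyl carbon in comparison with compound 3. Both measured steps keep the (2-aminophenyl)carbamoyl group, so they bear only loosely on this change. No step beyond the scatter is expected in this assay although the uncertainty is wide. The expected change is a 1.2-fold higher number from compound 3 to compound 4 (0.09 log units; within the scatter) in this estimate. For compound 4 the estimated value is 15000 nM with an expected range from 6000 nM to 40000 nM for the coming measurement.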

Compound 4, concentration for 50% growth inhibition: 5230 nM
Compound 4: the middle estimate sits 2.9-fold (0.46 log units) above what was measured; the whole stated range lies above it.
By their numbers in this assay, from the lowest: compounds 4, 2, 1 and 3 (each within the scatter of the next, the first and the last beyond it).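

In this assay the ((3-phenylpropyl)carbonyl)amino group gives a 2.3-fold lower number from compound 3 to compound 4 (0.37 log units; beyond the scatter) in place of (2-aminophenyl)carbamoyl, and a 2.2-fold lower number from compound 1 to compound 4 (0.35 log units; beyond the scatter) in place of ((2-aminophenyl)carbamoyl)methyl. Going by these compounds alone, both steps lie beyond the scatter, so this place on the chain responds to a change of the end group, whereas the earlier steps, which kept the (2-aminophenyl)carbamoyl group, stayed within it. No measurement shown here accounts for these steps.

Going by these compounds, whether the 3-phenylpropyl part or the amide link carries the step remains open. So does the outcome with a simple amine or a carboxylic acid at this place.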